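The source may hold more compounds than are shown below. What is called first, only, known or untested is meant among the compounds shown, and "the series" means these compounds.

Compound 1 `O=C1CSC(N2N=C(c3ccc(Cl)cc3)CC2c2ccc3ccccc3c2)=N1` was examined in a functional assay on HeLa cells (Homo sapiens) for inhibition, read by CCK-8 assay, with a stated time of 48 h (a higher number here means a weaker inhibitor, a lower number a stronger inhibitor), where compound 1 gives 6320 nM, the second highest of the three numbers recorded so far. Compound 2 `Clc1ccc(C2=NN(C3=NC(c4ccccc4)CS3)C(c3ccc4ccccc4c3)C2)cc1` gives 7560 nM; the step of a 1.2-fold higher number from compound 1 to compound 2 (0.08 log units; within the scatter) puts a larger ring-bearing group in place of a smaller one on the amine nitrogen in the ring. For the measured compounds named here, compound 3 `Cc1ccc(C2=NN(C3=NC(c4ccccc4)CS3)C(c3cccc4ccccc34)C2)cc1C` gives 1720 nM, a lower number than compound 1 and the furthest from it, beyond the scatter, though compound 3 differs from both compound 1 and compound 2 in more than one place, so no single step to it can be drawn. Compound 4 `Cc1ccc(C2=NN(C3=NC(=O)CS3)C(c3ccc4ccccc4c3)C2)cc1C` differs from compound 1 by 3,4-dimethylphenyl in place of 4-chlorophenyl on a carbon with a double bond to nitrogen. Going by the values given here, no measured step isolates this exchange; the comparison of compound 2 with compound 3 mixes it with a second change and only hints at a lower number. Compound 4 is therefore expected to give 3000 nM, within 1200 nM to 8000 nM, an estimated step of a 2.1-fold lower number from compound 1 to compound 4 (0.32 log units; beyond the scatter) that is expected to reach slightly beyond the scatter.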

Compound 4, half-maximal inhibitory concentration: 860 nM
Compound 4: middle estimate off by 3.5-fold (0.54 log units), on the high side; measured number outside the range, below it.
By their numbers in this assay, from the lowest: compounds 4 and 3 (each within the scatter of the next); then compounds 1 and 2 (each within the scatter of the next).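

In this assay, for the compounds shown here, placing 3,4-dimethylphenyl in place of 4-chlorophenyl on the carbon with a double bond to nitrogen gives a 7.3-fold lower number from compound 1 to compound 4 (0.87 log units; beyond the scatter), a step beyond the scatter, whereas the only earlier step, a 1.2-fold higher number from compound 1 to compound 2 (0.08 log units; within the scatter), lay within it and concerned a different place. Going by these compounds alone, this position, which no earlier step had isolated, therefore responds to an exchange of its aromatic group while the rest of compound 1 stays the same. No measurement bearing on the cause of this step is available.

Going by these compounds, what 4-methylphenyl, 3-methylphenyl, 4-methoxyphenyl or unsubstituted phenyl would give at this position remains open, as does whether one methyl group alone could account for the step. On these data alone, whether the same exchange would carry over to the larger group that compound 2 bears on the ring nitrogen also stays open.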